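The compounds below may be only part of what the source reports. "The series", "measured", "known", "first", "only" and "open" are said of these compounds alone.

Within the data shown here, compound 2 `CC/C(=C(/c1ccc(/C=C/C(=O)O)cc1)c1ccc2[nH]ncc2c1F)c1ccccc1` holds the lower of the two numbers measured so far in a functional assay on MCF7 cells (Homo sapiens) for cytotoxicity, read by CellTiter-Glo, with a stated time of 5 days (a higher number here means a weaker inhibitor, a lower number a stronger inhibitor), where compound 2 gives 3 nM; compound 1 `CC/C(=C(/c1ccc(/C=C/C(=O)O)cc1)c1ccc2[nH]ncc2c1)c1ccccc1` gives 7.2 nM. Among the measured compounds shown here, the only measured step, a 2.4-fold lower number from compound 1 to compound 2 (0.38 log units; beyond the scatter), came from fluoro in place of hydrogen on an aromatic carbon. Compound 3 `CC/C(=C(/c1ccc(/C=C/C(=O)O)cc1)c1ccc2[nH]ncc2c1OC)c1ccccc1` differs from compound 2 in this way: methoxy in place of fluoro on an aromatic carbon. For the measured compounds named here, no measured step swaps fluoro for methoxy, so that single earlier step is only a loose guide, and a small move in either direction, or none beyond the scatter, is plausible. Compound 3 is therefore expected to give 4 nM, between 1.5 nM and 12 nM, a step of a 1.3-fold higher number from compound 2 to compound 3 (0.12 log units; within the scatter).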

Compound 3, half-maximal inhibitory concentration: 55 nM
Beside the measured number, compound 3's estimate is 14-fold (1.14 log units) below it; measured number above the stated range.
By their numbers in this assay, from the lowest: compound 2; then compound 1; then compound 3.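

In this assay, this position proves sensitive to the group placed on it: methoxy in place of fluoro gives an 18-fold higher number from compound 2 to compound 3 (1.26 log units; beyond the scatter) and a large loss. Methoxy in place of hydrogen gives a 7.6-fold higher number from compound 1 to compound 3 (0.88 log units; beyond the scatter) as well, so the compound with hydrogen here lies between the other two, and a change at this one carbon can move the number either way. No evidence is available to explain this. Still open, as far as these compounds go, is whether chloro, hydroxyl or an amine here would track with fluoro or with methoxy.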